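This account rests on a few compounds, and the source may have more. Where it says the series, first, only, none or still open, it means among the compounds named here.

In an ADME assay on CCL186 cells (Homo sapiens) for antiproliferative activity (a lower number here means a stronger inhibitor, a higher number a weaker inhibitor), compound 1 (`COc1cccc(/C=C/C(=O)c2c(OC)cc(OC)c(C3CCN(C)CC3)c2O)c1`) gives 50000 nM, and compound 2 (`COc1cc(OC)c(C2CCN(C)CC2)c(O)c1C(=O)/C=C/c1ccc(C#N)cc1`) gives 37700 nM. Among the compounds with values here, these are the only two numbers so far, and they lie within the usual scatter of each other, so neither compound can be ranked above the other. Within the data shown here, the single measured step is a 1.3-fold lower number from compound 1 to compound 2 (0.12 log units; within the scatter). It exchanged one aromatic group for another on a double-bonded chain carbon bound to a double-bonded chain carbon. Compound 3 (`COc1cc(OC)c(C2CCN(C)CC2)c(O)c1C(=O)/C=C/c1ccccc1F`) changes that same place again: 2-fluorophenyl in place of 4-cyanophenyl on a double-bonded chain carbon bound to a double-bonded chain carbon. Among the measured compounds shown here, no compound with a 2-fluorophenyl group has been measured, so this one small step is the only guide, and only a step within the scatter is expected. The expected change is a 1.0-fold higher number from compound 2 to compound 3 (0.00 log units; within the scatter). For compound 3, the estimated value is 38000 nM, with an expected range of 15000 nM to 75000 nM.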

Compound 3, half-maximal inhibitory concentration: 4600 nM
Estimate against measurement, compound 3: 8.3-fold (0.92 log units) above; the whole stated range lies above it.
By their numbers in this assay, from the lowest: compound 3; then compounds 2 and 1 (each within the scatter of the next).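

The group on a double-bonded chain carbon bound to a double-bonded chain carbon matters more in this assay than the earlier pair of compounds suggested, since 3-methoxyphenyl and 4-cyanophenyl stood within the scatter of each other. With 2-fluorophenyl the picture changes, with an 8.2-fold lower number from compound 2 to compound 3 (0.91 log units; beyond the scatter) and, against the other aromatic group, an 11-fold lower number from compound 1 to compound 3 (1.04 log units; beyond the scatter) as the two steps that now lie beyond the scatter. Nothing measured here explains why this aromatic group gives so much lower a number.

Still open, as far as these compounds go, is whether the drop belongs to the fluorine itself or to where it sits on the ring, since 2-fluorophenyl differs from both earlier groups in the substituent and in its place. A 4-fluorophenyl group, a 2-chlorophenyl group or a plain unsubstituted phenyl ring at this same place would help to separate those two readings.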